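Amide Nitrogen Substituents and Cytotoxicity Toward HeLa Cells

A few compounds are considered here, and "the series" means these few. Any claim that something is new, unique, unknown or untested is made for them only; others in the source may bear on it.

Compound 1 `C=CC1=C(C(=O)NC(C)(C)C)C(c2ccc(OC)cc2)OC1`: > 100000 nM
Compound 2 `C=CC1=C(C(=O)Nc2ccc(OCC)cc2)C(c2ccc(OC)cc2)OC1`: > 100000 nM
Compound 3 `C=CC1=C(C(=O)NCCC)C(c2ccc(OC)cc2)OC1`: 14000 nM

In a functional assay on HeLa cells (Homo sapiens) for cytotoxicity, read by MTT assay, with a stated time of 24 h (on this read-out lower numbers stand for stronger inhibition and higher numbers for weaker inhibition), compound 1 reaches only the limit of the assay, > 100000 nM, and no number. Compound 2 likewise sits at the limit of this assay with > 100000 nM. Compound 3 is the only one of the three with a measured number, giving 14000 nM in this assay. For compound 1 and compound 2 only the limit is recorded, as the limit of > 100000 nM in this assay, at which 2 of the 3 values shown sit, shows. The step of an at least 7.1-fold lower number from compound 1 to compound 3 (0.85 log units; beyond the scatter) and the step of an at least 7.1-fold lower number from compound 2 to compound 3 (0.85 log units; beyond the scatter) both favour the propyl amide, while the step that the two limits leave unreadable from compound 1 to compound 2 cannot be read.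

Compound 4 `C=CC1=C(C(=O)NCc2ccc(C)cc2)C(c2ccc(OC)cc2)OC1` differs from compound 3 by 4-methylphenyl in place of ethyl on a saturated chain carbon bound to an amide-type nitrogen. For the measured compounds named here, compound 3 is the only measured reference; the two steps that reach it show that tert-butyl and 4-ethoxyphenyl on the amide nitrogen both give weaker inhibition than propyl, but no measured step covers a benzyl-type group. Compound 4 is therefore expected to land near compound 3, with a step of a 1.4-fold higher number from compound 3 to compound 4 (0.15 log units; within the scatter) in this assay, and a real chance of returning only a limit. The estimate for compound 4 is 20000 nM, with a range from 5000 nM to 100000 nM.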

Compound 4, half-maximal inhibitory concentration: 15900 nM
Beside the measured number, compound 4's estimate is 1.3-fold (0.10 log units) above it, within the range that was stated.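

In this assay, the 4-methylbenzyl group on the amide nitrogen gives no separation from the propyl group, with a 1.1-fold higher number from compound 3 to compound 4 (0.06 log units; within the scatter), so a chain carrying one six-membered aromatic ring of carbon only can stand at this place with no readable change. Carrying an aromatic ring is thus not enough to place a compound at the weak end of this short series, as an at least 6.2-fold lower number from compound 2 to compound 4 (0.79 log units; beyond the scatter) and an at least 6.2-fold lower number from compound 1 to compound 4 (0.79 log units; beyond the scatter) show. Compound 1 and compound 2 remain limits and not numbers, so these two steps are bounds only: the limit of > 100000 nM in this assay, at which 2 of the 4 values shown sit.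

The compounds shown leave open whether this level holds for a longer chain on the amide nitrogen, or for a chain ending in an amine or a carboxylic acid. They also leave open whether a plain benzyl group, without the methyl, would read the same.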